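The source may report more compounds than this note shows. Statements on the series, on what has been measured and on what is new or still open speak of the compounds shown alone.

Working notes on the series in a functional assay on SW-620 cells (Homo sapiens) for cytotoxicity, read by sulforhodamine B assay, with a stated time of 48 h; a higher number here means a weaker inhibitor, a lower number a stronger inhibitor.

Compound 1 `C[C@H]1CC[C@@H]2[C@@H](OC(=O)[C@]23CC(c2ccc(N(C)C)cc2)=NO3)[C@]2(C)C(=O)C=C[C@@]12O` sits at the low end of the three numbers seen so far; in this assay compound 1 gives 5100 nM. Compound 2 `C[C@H]1CC[C@@H]2[C@@H](OC(=O)[C@]23CC(c2ccc([N+](=O)[O-])cc2)=NO3)[C@]2(C)C(=O)C=C[C@@]12O` gives 9000 nM in this assay, and compound 3 `COc1ccc(C2=NO[C@]3(C2)C(=O)O[C@@H]2[C@H]3CC[C@H](C)[C@]3(O)C=CC(=O)[C@@]23C)cc1OC` gives 86000 nM. The change of substituent on the aromatic carbon gives a 1.8-fold higher number from compound 1 to compound 2 (0.25 log units; within the scatter), whereas the exchange of the whole aryl group gives a 17-fold higher number from compound 1 to compound 3 (1.23 log units; beyond the scatter) and a 9.6-fold higher number from compound 2 to compound 3 (0.98 log units; beyond the scatter). Going by the values given here, the sole step within the scatter is the one that keeps the aryl ring and alters only the group on its aromatic carbon.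

Compound 4 `C[C@H]1CC[C@@H]2[C@@H](OC(=O)[C@]23CC(c2ccc(C#N)cc2)=NO3)[C@]2(C)C(=O)C=C[C@@]12O` is not yet measured. Relative to compound 1 the difference is cyano in place of dimethylamino on an aromatic carbon. Among the compounds with values here, no measured step involves cyano, so the only bearing comes from the one change at the same aromatic carbon, a 1.8-fold higher number from compound 1 to compound 2 (0.25 log units; within the scatter), which stayed within the scatter. A step of similar size, upward if anything but not beyond the scatter, is therefore expected: a 1.6-fold higher number from compound 1 to compound 4 (0.20 log units; within the scatter). Compound 4 is estimated at 8000 nM in this assay, within a range from 3000 nM to 25000 nM.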

Compound 4, half-maximal inhibitory concentration: 53000 nM
Beside the measured number, compound 4's estimate is 6.6-fold (0.82 log units) below it; measured number above the stated range.
By their numbers in this assay, from the lowest: compounds 1 and 2 (each within the scatter of the next); then compounds 4 and 3 (each within the scatter of the next).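

In this assay, the group on this aromatic carbon can matter a great deal: a 10-fold higher number from compound 1 to compound 4 (1.02 log units; beyond the scatter) for cyano in place of dimethylamino, so the small step seen earlier with nitro does not hold for every replacement here. Nitro and cyano also part from each other, with a 5.9-fold higher number from compound 2 to compound 4 (0.77 log units; beyond the scatter), while a 1.6-fold lower number from compound 3 to compound 4 (0.21 log units; within the scatter) places the 4-cyanophenyl compound together with the 3,4-dimethoxyphenyl compound, so keeping a single substituent on the ring does not by itself keep compound 4 with compound 1 and compound 2. Nothing on hand accounts for this split among the groups.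

Open, on these data alone, is how an unsubstituted amine or a carboxylic acid on this aromatic carbon would read, and whether either would fall with compound 1 and compound 2 or with compound 3 and compound 4. Also open, as far as these compounds go, is whether the same order of these groups would hold on a different core.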